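Dimethylamino in place of tert-butyl on a carbonyl carbon

A few compounds are considered here, and "the series" means these few. Any claim that something is new, unique, unknown or untested is made for them only; others in the source may bear on it.

Measured so far in a physicochemical assay for solubility (a higher number here means a more soluble compound, a lower number a less soluble compound), for this series:
- compound 1 `CC(C)C(=O)N1CCC[C@H]1C(=O)N1CCC(NS(=O)(=O)c2cc(S(=O)(=O)c3ccccc3)ccc2C(F)(F)F)CC1` gives 100000 nM
- compound 2 `CC(C)(C)C(=O)N1CCC[C@H]1C(=O)N1CCC(NS(=O)(=O)c2cc(S(=O)(=O)c3ccccc3)ccc2C(F)(F)F)CC1` gives 50000 nM

Within the data shown here, compound 2 (50000 nM) lies within the scatter of compound 1 (100000 nM), the only other compound measured, so the numbers do not separate the two. Next in view is compound 3 `CN(C)C(=O)N1CCC[C@H]1C(=O)N1CCC(NS(=O)(=O)c2cc(S(=O)(=O)c3ccccc3)ccc2C(F)(F)F)CC1` with the structural change dimethylamino in place of tert-butyl on a carbonyl carbon. Among the measured compounds shown here, one measured step bears on this, and only indirectly. It is a 2.0-fold lower number from compound 1 to compound 2 (0.30 log units; within the scatter) for methyl in place of hydrogen on a saturated chain carbon bound to a carbonyl carbon. For the measured compounds named here, no measured step swaps tert-butyl for dimethylamino, so the data give no direct size for this change. On the strength of that one small step, no step beyond the scatter is expected in this assay and no direction is claimed. The estimate amounts to a 1.4-fold higher number from compound 2 to compound 3 (0.15 log units; within the scatter) as an expected step. Compound 3 is estimated at 70000 nM with an expected range from 25000 nM to 150000 nM in this read-out.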

Compound 3, solubility: 100000 nM
Beside the measured number, compound 3's estimate is 1.4-fold (0.15 log units) below it, and the stated range covers the measured number.
By their numbers in this assay, from the lowest: compounds 2, 1 and 3 (each within the scatter of the next).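

In this assay, dimethylamino in place of tert-butyl on a carbonyl carbon gives a 2.0-fold higher number from compound 2 to compound 3 (0.30 log units; within the scatter), and dimethylamino in place of isopropyl at the same place gives no change at the digits printed from compound 1 to compound 3 (within the scatter). The earlier pair varied only carbon groups on this carbonyl carbon, whereas compound 3 puts a nitrogen-bearing group there, and neither of its steps leaves the scatter, so this assay does not separate dimethylamino from either carbon group at this position. No measurement on hand accounts for these numbers or links them to any property of the groups.

Still open, going by these compounds, is whether any group on this carbonyl carbon can produce a step beyond the scatter in this assay, for example a carboxylic acid, a primary amine, a morpholine ring or a longer chain such as n-hexyl. Also open, on these data alone, is whether dimethylamino in place of tert-butyl would give a similar step on a different core, since all three compounds share the core of compound 1 and this change has been read only there.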